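Truncating the triazole-azide tail of the urea series

The source may hold more compounds than are shown below. What is called first, only, known or untested is meant among the compounds shown, and "the series" means these compounds.

Measured compounds:
compound 1, `CCOC(=O)c1cn(Cc2c(F)cccc2F)c2nc(-c3ccc(NC(=O)NCc4cn(CCN=[N+]=[N-])nn4)cc3)c(CN(C)Cc3ccccc3)n2c1=O`: 2570 nM
compound 2, `CCOC(=O)c1cn(Cc2c(F)cccc2F)c2nc(-c3ccc(NC(=O)NCc4cn(CCOCCOCCN=[N+]=[N-])nn4)cc3)c(CN(C)Cc3ccccc3)n2c1=O`: 2400 nM

Both numbers come from a functional assay on CHO cells for antagonist activity at Gonadotropin-releasing hormone receptor (Homo sapiens), read by a luciferase reporter, with a stated time of 30 min; a higher number here means a weaker inhibitor, a lower number a stronger inhibitor. Compound 1 stands at one end of the two numbers shown, but the step of a 1.1-fold lower number from compound 1 to compound 2 (0.03 log units; within the scatter) places compound 2 together with it within the scatter, so the two cannot be told apart on the evidence.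

Compound 3, `CCNC(=O)Nc1ccc(-c2nc3n(Cc4c(F)cccc4F)cc(C(=O)OCC)c(=O)n3c2CN(C)Cc2ccccc2)cc1`, is not yet measured in this assay. It differs from compound 1 as follows: methyl in place of 1-(2-azidoethyl)-1H-1,2,3-triazol-4-yl on a saturated chain carbon bound to an amide-type nitrogen. Within the data shown here, the only measured step, from compound 1 to compound 2, alters the part of that same tail that lies furthest from the urea; it is not a cut of the tail and bears only indirectly on the change to compound 3. What it does show is that lengthening the tail left this assay unmoved. Among the measured compounds shown here, no measured pair shows what happens when the whole triazole portion is replaced by methyl, so the expectation for compound 3 rests on that single indirect step and carries a wide range.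

Compound 3 is expected to give 1600 nM, between 400 nM and 6500 nM, which amounts to the estimated step of a 1.6-fold lower number from compound 1 to compound 3 (0.21 log units; within the scatter).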

Compound 3, half-maximal inhibitory concentration: 70.8 nM
Compound 3: the middle estimate sits 23-fold (1.35 log units) above what was measured, and the stated range ends above it.
By their numbers in this assay, from the lowest: compound 3; then compounds 2 and 1 (each within the scatter of the next).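

Methyl in place of 1-(2-azidoethyl)-1H-1,2,3-triazol-4-yl on a saturated chain carbon bound to an amide-type nitrogen gives, in this assay, a 36-fold lower number from compound 1 to compound 3 (1.56 log units; beyond the scatter) and is the first change in these notes to lie beyond the scatter. The earlier change, a 1.1-fold lower number from compound 1 to compound 2 (0.03 log units; within the scatter), altered only the far part of the tail and gave no readable shift, whereas this one removes the whole 1-(2-azidoethyl)-1H-1,2,3-triazol-4-yl group, with its 10 heavy atoms, and shows that the read-out at this position does respond to the group present. Nothing measured here accounts for the size of the step.

The compounds shown leave open whether the shift follows from losing the triazole ring, the azidoethyl part or the bulk of the group as a whole, since all of these leave together in this one change. A propyl chain, a benzyl group or a triazole carrying only a methyl on the same saturated chain carbon would separate these readings and show how much of the tail this position tolerates.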